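The compounds below may be only part of what the source reports. "The series", "measured", "known", "first", "only" and "open" are said of these compounds alone.

Working notes on the series. The shared core of compound 1 `COc1cccc(OC)c1C1CCCC(=O)N1Cc1ccccc1` carries an unsubstituted benzyl group; in a functional assay on CHO cells for antagonist activity at Orexin/Hypocretin receptor type 1 (Homo sapiens), read by FLIPR and calcium flux (on this read-out lower numbers stand for stronger inhibition and higher numbers for weaker inhibition), compound 1 gives 2420 nM. Compound 2 `COc1cccc(OC)c1C1CCCC(=O)N1Cc1cccc(OC(F)(F)F)c1` gives 136 nM, and compound 3 `COc1cccc(OC)c1C1CCCC(=O)N1Cc1cccc(-c2ccccc2)n1` gives 34 nM. Within these three numbers compound 2 stands second highest: the step of an 18-fold lower number from compound 1 to compound 2 (1.25 log units; beyond the scatter) separates it from compound 1, while compound 3 sits below it by a margin beyond the scatter.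

Compound 4 `COc1cccc(OC)c1C1CCCC(=O)N1Cc1cccc(-c2ncccn2)c1` is not yet measured. Relative to compound 2 the change is pyrimidin-2-yl in place of trifluoromethoxy on an aromatic carbon. For the measured compounds named here, no measured step covers this exchange directly. Going by the values given here, the only step that touches the same place is an 18-fold lower number from compound 1 to compound 2 (1.25 log units; beyond the scatter), which shows that the benzyl ring tolerates a substituent there with a large gain; compound 3, with a phenyl on a different ring, gives the lowest number of the three, so an aromatic substituent on the benzyl side is at least compatible with low numbers, though compound 3 is not a one-place comparison to compound 2 or compound 4.

Compound 4 is therefore expected to give a number near compound 2 or somewhat lower, roughly a 1.9-fold lower number from compound 2 to compound 4 (0.29 log units; within the scatter). The estimate for compound 4 is 70 nM, within 15 nM to 300 nM.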

Compound 4, half-maximal inhibitory concentration: 14 nM
Compound 4: the middle estimate sits 5.0-fold (0.70 log units) above what was measured; measured number outside the range, below it.
By their numbers in this assay, from the lowest: compound 4; then compound 3; then compound 2; then compound 1.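

At this place, on an aromatic carbon of a six-membered aromatic ring of carbon only, the exchange of trifluoromethoxy for pyrimidin-2-yl gives in this assay a 9.7-fold lower number from compound 2 to compound 4 (0.99 log units; beyond the scatter), so the gain at this carbon does not end with trifluoromethoxy and a six-membered aromatic ring with 2 hetero atoms takes it further. Measured against the unsubstituted benzyl group of compound 1, the new substituent gives a 170-fold lower number from compound 1 to compound 4 (2.24 log units; beyond the scatter), a clearly larger step than an 18-fold lower number from compound 1 to compound 2 (1.25 log units; beyond the scatter), which shows that this one aromatic carbon can carry much of the change in the number across the series. The data at hand offer no measurement that explains why pyrimidin-2-yl outperforms trifluoromethoxy here.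

As far as these compounds go, it remains open whether the two ring nitrogens of pyrimidin-2-yl matter, a question that a plain phenyl or a pyridin-2-yl group at this same carbon would address, as would a saturated ring such as morpholine for the need for an aromatic ring at all. Also open is whether the gain carries over to other carbons of this ring, since each one-place comparison shown concerns this single aromatic carbon.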